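This account rests on a few compounds, and the source may have more. Where it says the series, first, only, none or still open, it means among the compounds named here.

Measured compounds:
- Compound 1, `Nc1ccc2cccc(OC3CCCCCC3)c2n1`, 137 nM in an assay on cells with melanin-concentrating hormone receptor 1 (Homo sapiens) as the target, read by radioligand binding; on this read-out lower numbers stand for stronger inhibition and higher numbers for weaker inhibition
- Compound 2, `CCOCC(C)Oc1cccc2ccc(N)nc12`, 1070 nM in this assay
- Compound 3, `Nc1ccc2cccc(OCC3CC4CCC3C4)c2n1`, 137 nM in this assay

All three share the same core and differ only in the group attached through an oxygen on that core. Compound 2 carries an open chain there and gives the highest number of the three in this assay; its nearest neighbour, compound 1, gives a number beyond the scatter below it, and compound 3 stands at the same distance. Compound 1 and compound 3, which both carry a ring on that oxygen, give values that lie within the scatter of each other.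

Compound 4, `Nc1ccc2cccc(OC3CCC3)c2n1`, has not yet been measured in this assay. It differs from compound 2 in one place: a group of 4 heavy atoms (4 carbon; one four-membered non-aromatic ring of carbon only) in place of a group of 6 heavy atoms (5 carbon, 1 oxygen; no ring), on an oxygen on an aromatic ring. Since both measured ring-bearing compounds give lower numbers than compound 2, a step towards a lower number is expected from compound 2 to compound 4, though the ring entering here is smaller than either ring already seen, so the step is estimated as moderate, a 2.7-fold lower number from compound 2 to compound 4 (0.43 log units; beyond the scatter). The expected value for compound 4 is 400 nM, within the range from 120 nM to 1400 nM.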

Compound 4, half-maximal inhibitory concentration: > 2000 nM
Compound 4: a limit, no number; the forecaster's own chance of this, stated with the estimate: 5%; middle value at least 5.0-fold (0.69 log units) from the limit.
By their numbers in this assay, from the lowest: compounds 1 and 3 (each within the scatter of the next); then compound 2. At a limit, above all of these: compound 4.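

In this assay, compound 4 gives a limit and not a number: the limit of > 2000 nM in this assay, at which 1 of the 4 values shown sits.
Putting cyclobutyl in place of the open chain on this oxygen gives an at least 1.8-fold higher number from compound 2 to compound 4 (0.27 log units; that floor lies within the scatter), so this change brings no drop in the number. A ring on this oxygen is therefore not enough for a low number: compound 4 carries one and goes against the low values of compound 1, at 137 nM, and compound 3, at 137 nM.

The compounds shown leave open how far the true number of compound 4 lies past its limit, and how the number moves between cyclobutyl and the larger ring groups, for instance with cyclopentyl or cyclohexyl on the same oxygen. They also leave open what a chain ending in an amine would give there.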